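The source may report more compounds than this note shows. Statements on the series, on what has been measured and on what is new or still open speak of the compounds shown alone.

Three measured compounds share a core in which a cyclopentane carries a sulfone, a nitrile-bearing amide and a second amide to a cyclic amine. Compound 1 `N#CCNC(=O)[C@@H]1C[C@@H](S(=O)(=O)c2ccccc2C(F)(F)F)C[C@H]1C(=O)N1CCOCC1` gives 0.9 nM in an assay on isolated protein for inhibition of cathepsin S (Homo sapiens), read by fluorescence, with a stated time of 20 min; on this read-out lower numbers stand for stronger inhibition and higher numbers for weaker inhibition. Compound 2 `CC(C)(C#N)NC(=O)[C@@H]1C[C@@H](S(=O)(=O)c2ccccc2)C[C@H]1C(=O)N1CCOCC1` gives 3 nM in this assay. Compound 3 `N#CC1(NC(=O)[C@@H]2C[C@@H](S(=O)(=O)c3ccccc3)C[C@H]2C(=O)N2CCCCC2)CC1` gives 0.8 nM in this assay, the lowest of the three numbers; compound 1 sits closest and within the usual scatter of it, while compound 2 lies furthest and beyond the scatter.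

Compound 4 `CN(C)C(=O)[C@@H]1C[C@H](S(=O)(=O)c2ccccc2)C[C@H]1C(=O)NC1(C#N)CC1` has not yet been measured in this assay. It differs from compound 3 in one place: dimethylamino in place of piperidin-1-yl on a carbonyl carbon. Within the data shown here, no pair of measured compounds shows this exact swap in isolation, so the step has to be judged from the surrounding numbers. Compound 3, at 0.8 nM, and compound 1, at 0.9 nM, show that a change of the ring amine at this carbonyl can leave the number nearly unchanged. A small step toward weaker inhibition, or none beyond the scatter, is expected in this assay, as a 2.3-fold higher number from compound 3 to compound 4 (0.35 log units; beyond the scatter). Compound 4 is therefore estimated at 1.8 nM, within a range from 0.6 nM to 6 nM.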

Compound 4, half-maximal inhibitory concentration: 6 nM
The estimate for compound 4 lay 3.3-fold (0.52 log units) below the measured number; the measured number falls inside the stated range.
By their numbers in this assay, from the lowest: compounds 3 and 1 (each within the scatter of the next); then compounds 2 and 4 (each within the scatter of the next).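

In this assay, dimethylamino in place of piperidin-1-yl on a carbonyl carbon gives a 7.5-fold higher number from compound 3 to compound 4 (0.88 log units; beyond the scatter), a modest step but one beyond the usual scatter. Among these compounds, the earlier compounds differed from one another in more than one place, so this is the first direct reading of this position alone, and it shows that the number responds to the group on this carbonyl carbon. Nothing measured here explains why the number rises with this change.

The swap removes a ring and also reduces the heavy atoms from 6 to 3, so the compounds shown leave open which of these two differences matters. Diethylamino, which has no ring, or pyrrolidin-1-yl, which keeps a smaller ring, on the same carbonyl carbon would help to separate them.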